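The compounds below may be only part of what the source reports. "The series", "measured", "known", "first", "only" and "open" are said of these compounds alone.

Of the compounds shown here, three sharing one core have been measured in a functional assay on DU-145 cells (Homo sapiens) for cytotoxicity, read by MTT assay; on this read-out higher numbers stand for weaker inhibition and lower numbers for stronger inhibition. Compound 1, `CCC(C)(O)CC(=O)O[C@H](CC=C(C)C)C1=CC(=O)c2c(O)ccc(O)c2C1=O`, gives 16000 nM. Compound 3, `CCC(O)(CC)CC(=O)O[C@H](CC=C(C)C)C1=CC(=O)c2c(O)ccc(O)c2C1=O`, gives 67000 nM, the highest of the two numbers, with a 4.2-fold higher number from compound 1 to compound 3 (0.62 log units; beyond the scatter) separating it from compound 1. Compound 2, `CC(C)=CC[C@@H](OC(=O)CC(C)(O)c1ccccc1)C1=CC(=O)c2c(O)ccc(O)c2C1=O`, reaches only the limit of this assay at > 100000 nM. That limit, (the limit of > 100000 nM in this assay, at which 1 of the 3 values shown sits), is what stands behind an at least 6.2-fold higher number from compound 1 to compound 2 (0.79 log units; beyond the scatter) and behind an at least 1.4-fold lower number from compound 2 to compound 3 (0.17 log units; that floor lies within the scatter), which lies within the scatter.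

Compound 4, `CCCCC(CC(=O)O[C@H](CC=C(C)C)C1=CC(=O)c2c(O)ccc(O)c2C1=O)OC(C)=O`, differs from compound 3 by 1-acetoxypentyl in place of 1-ethyl-1-hydroxypropyl on a saturated chain carbon bound to a carbonyl carbon. Within the data shown here, no measured step touches an acetoxy group; the nearest evidence is a 4.2-fold higher number from compound 1 to compound 3 (0.62 log units; beyond the scatter), where a methyl in place of hydrogen on the saturated chain carbon raised the number, and an at least 6.2-fold higher number from compound 1 to compound 2 (0.79 log units; beyond the scatter), where a phenyl did so as well. Both point to larger groups at that position giving higher numbers, so compound 4 is expected to stay near compound 3 or drift higher. The step from compound 3 is estimated at a 1.0-fold higher number from compound 3 to compound 4 (0.02 log units; within the scatter). Compound 4 is therefore expected to give 70000 nM, within 25000 nM to 200000 nM.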

Compound 4, half-maximal inhibitory concentration: 67700 nM
Compound 4: the middle estimate sits 1.0-fold (0.01 log units) above what was measured; the measured number falls inside the stated range.
By their numbers in this assay, from the lowest: compound 1; then compounds 3 and 4 (each within the scatter of the next). At a limit, above all of these: compound 2.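

Among these compounds, compound 4 is the first in this set to carry no hydrogen-bond donor in the group on the saturated chain carbon bound to a carbonyl carbon, yet replacing 1-ethyl-1-hydroxypropyl with 1-acetoxypentyl gives a 1.0-fold higher number from compound 3 to compound 4 (0.00 log units; within the scatter). The two structurally different groups thus stand level, and both remain separated from the group in compound 1, with a 4.2-fold higher number from compound 1 to compound 4 (0.63 log units; beyond the scatter). The step of an at least 1.4-fold lower number from compound 2 to compound 4 (0.16 log units; that floor lies within the scatter) rests on a limit, so it gives only a floor and its size cannot be read: the limit of > 100000 nM in this assay, at which 1 of the 4 values shown sits.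

The acetoxy group and the longer chain enter together in compound 4, so their separate contributions remain unresolved. As far as these compounds go, it also remains open how a plain pentyl chain, a free hydroxyl on that chain, an amine or a carboxylic acid would read at this place.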